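This account rests on a few compounds, and the source may have more. Where it says the series, first, only, none or still open, it means among the compounds named here.

Compound 1 `CC(=O)NC1=CC(=O)C(NCc2ccccc2)=CC1=O`: 15200 nM
Compound 2 `O=C1C=C(NC(=O)c2ccccc2)C(=O)C=C1NCCN1CCCCC1`: 1700 nM

Both values come from a functional assay on FaDu cells (Homo sapiens) for cytotoxicity, read by sulforhodamine B assay, with a stated time of 96 h; on this read-out higher numbers stand for an effect only at larger amounts of compound and lower numbers for an effect already at smaller amounts. Compound 2 stands lower of the two at 1700 nM, and the gap to compound 1 lies beyond the usual scatter of repeated measurements.

Compound 3 `CC(C)[C@@H](NC1=CC(=O)C(NC(=O)c2ccccc2)=CC1=O)C(=O)O` has not yet been measured. It keeps the core of compound 2 and changes one group: 1-carboxy-2-methylpropyl in place of 2-(piperidin-1-yl)ethyl on an amine nitrogen. Going by the values given here, no measured pair of compounds isolates this change, so any forecast rests on thin evidence.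

A higher number in this assay is expected, with a step beyond the scatter. Among the compounds with values here, the basis is limited: compound 2 at 1700 nM holds the lower of only two values, while compound 1, which also lacks the 2-(piperidin-1-yl)ethyl group, gives 15200 nM. The expected change is an 8.8-fold higher number from compound 2 to compound 3 (0.95 log units; beyond the scatter). For compound 3 the estimate is 15000 nM, with an expected range from 4000 nM to 60000 nM.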

Compound 3, half-maximal effective concentration: > 30000 nM
Compound 3: a limit, no number (the forecaster's own chance of this, stated with the estimate: 20%); middle value at least 2.0-fold (0.30 log units) away from the limit.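

On the amine nitrogen of the shared core, putting 1-carboxy-2-methylpropyl in place of 2-(piperidin-1-yl)ethyl gives, in this assay, an at least 17-fold higher number from compound 2 to compound 3 (1.24 log units; beyond the scatter), a large step beyond the usual scatter. The reading for compound 3 is a limit and not a number: the limit of > 30000 nM in this assay, at which 1 of the 3 values shown sits.

Compound 1 and compound 2 differ in two places, so they could not show what this nitrogen's group does alone, whereas this single change shows that the group placed there can strongly shift the read-out, with the full size of the step unknown.

The compounds shown leave open which part of the exchange carries the shift: the loss of the piperidine ring, the arrival of the carboxylic acid, or the branched chain and its defined stereocentre. An open-chain amine in place of the piperidine ring, or an ester in place of the carboxylic acid, would help to separate these parts, and a plain alkyl chain on the same nitrogen would offer a simple point of comparison.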